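A few compounds are considered here, and "the series" means these few. Any claim that something is new, unique, unknown or untested is made for them only; others in the source may bear on it.

In a physicochemical assay for solubility, read by HPLC, using the shake flask method, in phosphate buffer, measured as kinetic solubility, with a stated time of 20 h, at pH 6.5 (a higher number here means a more soluble compound, a lower number a less soluble compound), compound 1 `Fc1ccc(Nc2cc3[nH]c(Nc4cc(N5CCNCC5)ccn4)nc3cn2)cc1C(F)(F)F` gives 95000 nM, while compound 2 `Fc1ccc(Nc2cc3[nH]c(Nc4ccc(N5CCN(C6CC6)CC5)cn4)nc3cn2)cc1C(F)(F)F` gives 5000 nM, the lower of the two numbers and a gap beyond the usual scatter of repeat measurements. Compound 3 `C[C@@H]1CN(c2ccc(Nc3nc4cnc(Nc5ccc(F)c(C(F)(F)F)c5)cc4[nH]3)nc2)C[C@H](C)O1` keeps the core of compound 2 but carries 2,6-dimethylmorpholin-4-yl in place of 4-cyclopropylpiperazin-1-yl on an aromatic carbon. Among the measured compounds shown here, no measured pair of compounds shows this change on its own, so any forecast is uncertain. A drop beyond the scatter is expected, with an estimated step of a 5.0-fold lower number from compound 2 to compound 3 (0.70 log units; beyond the scatter). Compound 3 is estimated at 1000 nM, with an expected range of 200 nM to 5000 nM.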

Compound 3, solubility: < 5000 nM
Compound 3: no number, only a limit (the forecaster's own chance of this, stated with the estimate: 10%); the middle value lies beyond the limit too.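

For compound 3 the reading in this assay is a limit of the assay and not a number: the limit of < 5000 nM in this assay, at which 1 of the 3 values shown sits. Among the compounds shown here, putting 2,6-dimethylmorpholin-4-yl in place of 4-cyclopropylpiperazin-1-yl on this aromatic carbon gives a number no higher from compound 2 to compound 3 (the limit leaves the size open), so the swap brings no rise at this position, something the earlier compounds could not show. Still open, going by these compounds, is how far compound 3 really lies from its limit. Also open, on these data alone, is what a plain morpholin-4-yl without the two methyl groups, or a dimethylamino group, would give at the same position.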